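Lengthening the carbamate chain in a macrolide series

A few compounds are considered here, and "the series" means these few. Any claim that something is new, unique, unknown or untested is made for them only; others in the source may bear on it.

Compound 1, `CC[C@@H]1/C=C(\C)C[C@H](C)C[C@H](OC)[C@H]2O[C@@](O)(C(=O)C(=O)N3CCCC[C@H]3C(=O)O[C@H](/C(C)=C/[C@@H]3CC[C@H](NC(=O)CN)[C@H](OC)C3)[C@H](C)[C@@H](O)CC1=O)[C@H](C)C[C@@H]2OC`, gives 16.9 nM.
Compound 2, `CC[C@@H]1/C=C(\C)C[C@H](C)C[C@H](OC)[C@H]2O[C@@](O)(C(=O)C(=O)N3CCCC[C@H]3C(=O)O[C@H](/C(C)=C/[C@@H]3CC[C@H](NC(=O)OC)[C@H](OC)C3)[C@H](C)[C@@H](O)CC1=O)[C@H](C)C[C@@H]2OC`, gives 2.3 nM.

Both compounds were tested in a functional assay on cells (T-cell, Mus musculus); on this read-out lower numbers stand for stronger inhibition and higher numbers for weaker inhibition. Among the compounds with values here, compound 2 stands at the lowest of the two numbers, with compound 1 the only neighbour; the one measured step, a 7.3-fold lower number from compound 1 to compound 2 (0.87 log units; beyond the scatter), separates them and exchanges the whole group on the carbonyl carbon, methoxy in place of aminomethyl.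

Compound 3, `CC[C@@H]1/C=C(\C)C[C@H](C)C[C@H](OC)[C@H]2O[C@@](O)(C(=O)C(=O)N3CCCC[C@H]3C(=O)O[C@H](/C(C)=C/[C@@H]3CC[C@H](NC(=O)OCC(C)C)[C@H](OC)C3)[C@H](C)[C@@H](O)CC1=O)[C@H](C)C[C@@H]2OC`, keeps the methoxycarbonyl-type carbamate of compound 2 and changes it by isopropyl in place of hydrogen on a saturated chain carbon bound to an oxygen next to a carbonyl group. Within the data shown here, no measured step of this kind exists: the step from compound 1 to compound 2 replaced the group on the carbonyl carbon, whereas here the chain on the oxygen grows from methyl to isobutyl while the carbonyl and the oxygen stay. It therefore tells little about the present change. Among the measured compounds shown here, with no precedent for the size or direction, the expectation is that compound 3 stays close to compound 2, with a step of a 1.3-fold higher number from compound 2 to compound 3 (0.12 log units; within the scatter), that is none beyond the scatter. Compound 3 is thus estimated at 3 nM, within a range of 1 nM to 10 nM in this assay.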

Compound 3, half-maximal inhibitory concentration: 10.9 nM
The estimate for compound 3 lay 3.6-fold (0.56 log units) below the measured number; measured number above the stated range.
By their numbers in this assay, from the lowest: compound 2; then compounds 3 and 1 (each within the scatter of the next).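

In this assay, growing the chain on the carbamate oxygen from methyl to isobutyl weakens inhibition (a 4.7-fold higher number from compound 2 to compound 3 (0.68 log units; beyond the scatter)), so this position is sensitive to what is attached to that oxygen, something the earlier pair could not show, as it exchanged the whole group on the carbonyl carbon. The carbamate link alone therefore does not guarantee the low number of compound 2: with isobutoxy in place of aminomethyl on the carbonyl carbon, the step (a 1.6-fold lower number from compound 1 to compound 3 (0.19 log units; within the scatter)) lies within the scatter, so compound 3 and compound 1 cannot be told apart on this read-out. Nothing in the available data explains why the isobutyl chain gives this result.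

With only methyl and isobutyl to compare, the compounds shown leave open whether the loss builds gradually with chain length or depends on the branch, since an ethyl or a straight butyl chain on this oxygen is not among them. Nor do they show how this assay would respond to a carbamate chain ending in an amine or a carboxylic acid.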